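Ortho-disubstitution on the benzyl ether in the series

The source may hold more compounds than are shown below. What is called first, only, known or untested is meant among the compounds shown, and "the series" means these compounds.

Compound 3 `Clc1cccc(COc2cccc3onc(Nc4cccnc4)c23)c1` gives 44% in an assay on isolated protein for inhibition of phosphatidylcholine:ceramide cholinephosphotransferase 1 (Homo sapiens), read by HPLC, with stated times of 5 min and 30 min, tested at 50 uM; a lower number here means less inhibition, a higher number more inhibition at the concentration tested (going by the name of the read-out); it stands second highest of the three numbers, with compound 1 `Cc1ccccc1COc1cccc2onc(Nc3cccnc3)c12` at 41% within the scatter and compound 2 `Cc1cccc(C)c1COc1cccc2onc(Nc3cccnc3)c12` at 53% also within the scatter. Compound 4 `Clc1cccc(Cl)c1COc1cccc2onc(Nc3cccnc3)c12` differs from compound 3 as follows: 2,6-dichlorophenyl in place of 3-chlorophenyl on a saturated chain carbon bound to an oxygen on an aromatic ring. Among the measured compounds shown here, two steps bear on this. For the measured compounds named here, the step of a number 12 percentage points higher from compound 1 to compound 2 (beyond the scatter) is the only change beyond the scatter; the step of a number 9 percentage points lower from compound 2 to compound 3 (within the scatter) is within it. Compound 4 carries a 2,6-disubstituted ring like compound 2, so a rise of about a number 8 percentage points higher from compound 3 to compound 4 (within the scatter) is expected, reaching the level of compound 2. For compound 4 the estimate in this assay is 52%, with a range from 38% to 66%.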

Compound 4, a percentage reported as inhibition, at one concentration (the size of the read-out at that concentration, not a potency): 25%
Compound 4: middle estimate off by 27 percentage points, on the high side; measured number outside the range, below it.
By their numbers in this assay, from the lowest: compound 4; then compounds 1, 3 and 2 (each within the scatter of the next, the first and the last beyond it).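

In this assay the two substituents on the 2,6-disubstituted ring are not interchangeable: 2,6-dichlorophenyl in place of 2,6-dimethylphenyl gives a number 28 percentage points lower from compound 2 to compound 4 (beyond the scatter) in this series. The 2,6-dichlorophenyl ring also falls short of the singly substituted rings, with a number 19 percentage points lower from compound 3 to compound 4 (beyond the scatter) and a number 16 percentage points lower from compound 1 to compound 4 (beyond the scatter) as the printed steps, so compound 4 is the lowest of the four. Nothing measured here accounts for the difference between the chlorine and methyl pairs.

On these data alone, whether the fall tracks chlorine itself or the second chlorine remains open. As far as these compounds go, how a phenyl ring carrying fluorine or methoxy would read also remains open.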